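The source may report more compounds than this note shows. Statements on the series, on what has been measured and on what is new or still open speak of the compounds shown alone.

Three compounds share a fused two-ring core carrying a cyano group and two amino groups, and all three were tested in a functional assay on SK-OV-3 cells (Homo sapiens) for cytotoxicity, read by MTT assay; on this read-out lower numbers stand for stronger inhibition and higher numbers for weaker inhibition. Compound 1, `CC(C)(C)Nc1c(C#N)c(F)c2c(N)nc(N)nc2c1Cl`, gives 2.1 ug/mL in this assay. Compound 2, `CC(C)(C)Nc1c(C#N)c(F)c2c(N)nc(N)nc2c1F`, differs from compound 1 only by fluoro in place of chloro on an aromatic carbon, and in this assay compound 2 gives 2.4 ug/mL. The step of a 1.1-fold higher number from compound 1 to compound 2 (0.06 log units; within the scatter) therefore shows no real separation between the two. Compound 3, `N#Cc1c(NCc2ccccc2)c(Cl)c2nc(N)nc(N)c2c1NCc1ccccc1`, carries benzylamino groups instead of the (tert-butyl)amino group; how its core differs from the core of compound 1 is not broken down here. In this assay compound 3 gives 3.7 ug/mL, a number that lies within the scatter of both compound 1 and compound 2, so no order among the three can be read from these values.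

Compound 4, `N#Cc1c(NCc2ccccc2)c(F)c2nc(N)nc(N)c2c1NCc1ccccc1`, has not yet been measured. It differs from compound 3 by fluoro in place of chloro on an aromatic carbon. Going by the values given here, this is the same kind of change as the one from compound 1 to compound 2, though not the same: in compound 1 the place is ortho to a (tert-butyl)amino group and para to a fluoro group, whereas in compound 3 it is ortho to a benzylamino group and para to a benzylamino group. Since the earlier step was a 1.1-fold higher number from compound 1 to compound 2 (0.06 log units; within the scatter), a step of similar size is expected here, a 1.1-fold higher number from compound 3 to compound 4 (0.04 log units; within the scatter). The expected value for compound 4 in this assay is 4.1 ug/mL, with a range of 2 ug/mL to 8.5 ug/mL, resting on compound 3 at 3.7 ug/mL and on the small step seen between compound 1 and compound 2.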

Compound 4, half-maximal inhibitory concentration: 2.5 ug/mL
Compound 4: the middle estimate sits 1.6-fold (0.21 log units) above what was measured, within the range that was stated.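

Putting fluoro in place of chloro on a second core gives a 1.5-fold lower number from compound 3 to compound 4 (0.17 log units; within the scatter) in this assay, so this pair shows no real separation, just as the first pair showed none. Set side by side, the two steps cannot be told apart: the same change on two cores in this assay, a 1.1-fold higher number (0.06 log units; within the scatter) from compound 1 to compound 2 and a 1.5-fold lower number (0.17 log units; within the scatter) from compound 3 to compound 4, 1.7-fold (0.23 log units) apart, within the scatter of two such steps. This shows that, on the two cores tested here, the change from chloro to fluoro has no readable effect on the cytotoxicity numbers, and that the result on one core did not fail to hold on the other; it does not show that the change would be just as silent on other cores, and with steps this small, it cannot settle whether a slight real effect exists or which way it would point.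

The compounds shown leave open whether a bromo group or a methyl group at this same place would stand apart from chloro and fluoro, since only these two halogens are compared here. They also leave open what a carboxylic acid in place of the cyano group, or a longer straight-chain amine in place of the benzylamino groups, would do to the numbers in this assay.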